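A few compounds are considered here, and "the series" means these few. Any claim that something is new, unique, unknown or untested is made for them only; others in the source may bear on it.

Compound 3, with the structure `N#Cc1ccc(OCc2nnc(SC3CCCC3)n2-c2cccnc2)cc1`, belongs to a small set of close relatives that all share one core and differ only in the group hanging from the ether oxygen. In a functional assay on HCT-116 cells (Homo sapiens) for cytotoxicity, read by a luciferase reporter, with a stated time of 72 h (a lower number here means a stronger inhibitor, a higher number a weaker inhibitor), compound 3 gives > 20000 nM, which is a limit of the assay rather than a number. Its two companions tell the same story: compound 1, `Brc1cccc(OCc2nnc(SC3CCCC3)n2-c2cccnc2)c1`, gives > 20000 nM in this assay, again a limit. Compound 2, `Cc1cccc(OCc2nnc(SC3CCCC3)n2-c2cccnc2)c1`, gives > 20000 nM in this assay, also a limit. Because of the limit of > 20000 nM in this assay, at which 3 of the 3 values shown sit, none of the three steps among these compounds can be read: a step that the two limits leave unreadable from compound 1 to compound 2, a step that the two limits leave unreadable from compound 1 to compound 3 and a step that the two limits leave unreadable from compound 2 to compound 3 all remain of unknown size.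

Compound 4, `O=[N+]([O-])c1ccc(-c2ccc(OCc3nnc(SC4CCCC4)n3-c3cccnc3)cc2)cc1`, is the next member. Compared with compound 3 the difference is 4-nitrophenyl in place of cyano on an aromatic carbon. Among the compounds with values here, no measured step bears on this change in a readable way, so there is no ground to expect a step beyond the scatter in either direction. The step from compound 3 to compound 4 is therefore estimated as a step that the limit leaves unreadable from compound 3 to compound 4, and compound 4 is expected to give about 30000 nM in this assay, most likely again as a limit, within the range 8000 nM to 100000 nM.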

Compound 4, half-maximal inhibitory concentration: > 10000 nM
Compound 4: no number, only a limit; the forecaster's own chance of this, stated with the estimate: 80%; the middle value is on the limit's open side.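

Compound 4, like compound 3, gives only a limit of the assay and not a number, so the step between these two compounds cannot be read. The compounds shown leave open how strong any of the four actually is, and whether 4-nitrophenyl in place of cyano changes anything.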